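The source may hold more compounds than are shown below. What is called first, only, known or untested is meant among the compounds shown, and "the series" means these compounds.

Of the compounds shown here, three built on one shared core have been tested in an assay on HEK293 cells for agonist activity at transient receptor potential cation channel subfamily M member 8 (Homo sapiens), read by fluorescence and calcium flux, with a stated time of 15 min; a higher number here means that more compound is needed for the effect, a lower number that less compound is needed. Compound 1 `Cc1ccc(OCC(=O)N(Cc2cccs2)c2ccn(C)n2)cc1` gives 855 nM, compound 2 `Cc1ccc(OCC(=O)N(C)Cc2cccs2)cc1` gives 400 nM, and compound 3 `Cc1ccc(OCC(=O)N(O)Cc2cccs2)cc1` gives 8000 nM. Compound 3 therefore stands at the top of the three numbers, needing the most compound: the step of a 9.4-fold higher number from compound 1 to compound 3 (0.97 log units; beyond the scatter) and the step of a 20-fold higher number from compound 2 to compound 3 (1.30 log units; beyond the scatter) both go well beyond the scatter, and the step of a 2.1-fold lower number from compound 1 to compound 2 (0.33 log units; beyond the scatter) is the smallest of the three.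

Compound 4 `Cc1ccc(OCC(=O)N(Cc2cccs2)c2ccon2)cc1` carries the change (1,2-oxazol-3-yl in place of hydroxy on an amide-type nitrogen). The closest guide is the step from compound 1 to compound 3, where a five-membered aromatic ring with two hetero atoms was swapped for hydroxy and the number rose strongly; the change to compound 4 runs that swap backwards with a closely related ring. A drop of roughly the same size is therefore expected, in the direction of less compound being needed, as the step of an 8.0-fold lower number from compound 3 to compound 4 (0.90 log units; beyond the scatter). Compound 4 is expected to give about 1000 nM, within a range from 300 nM to 3500 nM.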

Compound 4, half-maximal effective concentration: 2 nM
Compound 4: middle estimate off by 500-fold (2.70 log units), on the high side; the measured number lies below the stated range.
By their numbers in this assay, from the lowest: compound 4; then compound 2; then compound 1; then compound 3.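

At this amide-type nitrogen, the identity of the ring matters greatly: in this assay, exchanging one five-membered aromatic ring with 2 hetero atoms for another gives a 430-fold lower number from compound 1 to compound 4 (2.63 log units; beyond the scatter) as the reverse reading of that swap. Compound 1 had made a ring look no better than methyl, but 1,2-oxazol-3-yl outdoes both small groups, with a 200-fold lower number from compound 2 to compound 4 (2.30 log units; beyond the scatter) against methyl and a 4000-fold lower number from compound 3 to compound 4 (3.60 log units; beyond the scatter) against hydroxy. Nothing available explains why this ring does so much better.

The ring swap also removes a methyl group, so a 1H-pyrazol-3-yl ring without that methyl would be needed to tell which part of the change counts. Also open, as far as these compounds go, is how a phenyl ring or a longer chain such as ethyl would fare on this nitrogen.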